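Replacing Fluoro with Methyl on a Fused Aromatic Core

The source may hold more compounds than are shown below. What is called first, only, known or untested is meant among the compounds shown, and "the series" means these compounds.

Of the compounds shown here, three sharing one core have been tested in a functional assay for binding affinity to Norepinephrine transporter (Rattus norvegicus), read by radioligand binding, in the presence of a further agent that is not named here; a higher number here means a weaker inhibitor, a lower number a stronger inhibitor. Compound 1 `COc1cccc2c1C=C(CC1CN=CN1)CC2` gives 1000 nM. Among the measured compounds shown here, compound 2 `Cc1cccc2c1C=C(CC1CN=CN1)CC2` gives 1000 nM, and the single step from compound 1 to compound 2, a methyl in place of methoxy on an aromatic carbon, shows no change at the digits printed from compound 1 to compound 2 (within the scatter). Compound 3 `Fc1ccc2c(c1)C=C(CC1CN=CN1)CC2` gives 50.1 nM, the lowest of the three numbers and a step beyond the scatter from both compound 1 and compound 2, so compound 3 is the strongest inhibitor here.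

Compound 4 `Cc1ccc2c(c1)C=C(CC1CN=CN1)CC2` differs from compound 3 in one place: methyl in place of fluoro on an aromatic carbon. For the measured compounds named here, no measured step swaps fluoro for methyl; the only measured step, from compound 1 to compound 2, exchanges two other groups and left the number unchanged, and compound 1 and compound 2 differ from compound 3 in more than one respect. The expected step is therefore a 2.0-fold higher number from compound 3 to compound 4 (0.30 log units; within the scatter), a modest rise in the number. Compound 4 is estimated at 100 nM, with a range from 25 nM to 400 nM.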

Compound 4, inhibition constant: 1000 nM
For compound 4 the middle estimate is 10-fold (1.00 log units) below the measured one; measured number above the stated range.
By their numbers in this assay, from the lowest: compound 3; then compounds 1, 2 and 4 (each within the scatter of the next).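

At this position, on an aromatic carbon meta to a fused ring and para to a fused ring, exchanging one group for another of a single heavy atom has a large effect in this assay: methyl in place of fluoro gives a 20-fold higher number from compound 3 to compound 4 (1.30 log units; beyond the scatter). Among the compounds shown here, the only earlier single step, methyl in place of methoxy, gave no change at the digits printed from compound 1 to compound 2 (within the scatter), so that step gave no sign that one small exchange on this core could matter so much, and the counts of heavy atoms, hydrogen-bond donors and acceptors are the same for fluoro and methyl. Nothing measured here accounts for the gap between these two groups.

From the compounds shown here alone, whether fluoro stands out at this position, or methyl alone gives the weaker result, remains open, and a chlorine atom, a hydroxyl or an amine on the same carbon would help to tell. Going by these compounds, it is also open whether fluoro would give a similar number on the carbon that carries methoxy in compound 1.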